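Replacing pyridin-3-yl on the shared core

This account rests on a few compounds, and the source may have more. Where it says the series, first, only, none or still open, it means among the compounds named here.

In an ADME assay on cells (Homo sapiens) for cytotoxicity, read by resazurin assay, with a stated time of 5 days (on this read-out higher numbers stand for lower toxicity in this test and lower numbers for higher toxicity in this test), compound 1 `COc1ccc(Nc2nc(CS(=O)(=O)c3cccc(Cl)c3)nc3ccsc23)cc1` gives 60000 nM. Compound 2 `O=S(=O)(Cc1nc(-c2cccnc2)c2sccc2n1)c1cccc(Cl)c1` gives > 50000 nM, which is a limit of the assay and not a number, so compound 2 has no exact position in the series. This reading sits at the assay limit described by the limit of > 50000 nM in this assay, at which 1 of the 2 values shown sits.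

Compound 3 `O=c1ccc(-c2nc(CS(=O)(=O)c3cccc(Cl)c3)nc3ccsc23)c[nH]1` keeps the shared core and changes only the group on an aromatic carbon, opposite the ring nitrogen: a group of 7 heavy atoms (5 carbon, 1 nitrogen, 1 oxygen; one six-membered aromatic ring with 1 hetero atom) in place of a group of 6 heavy atoms (5 carbon, 1 nitrogen; one six-membered aromatic ring with 1 hetero atom), on an aromatic carbon. The entering group has one six-membered aromatic ring with 1 hetero atom, as the leaving pyridin-3-yl does, and adds a double bond outside aromatic rings.

Within the data shown here, only one measured step bears on this position, a step that the limit leaves unreadable from compound 1 to compound 2, and its size cannot be read. Among the measured compounds shown here, no measured step covers this exact replacement. Compound 1 at 60000 nM therefore provides the only numerical anchor for the expectation in this assay.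

The expected step, a step that the limit leaves unreadable from compound 2 to compound 3, is estimated to stay within the usual scatter, with no direction favoured. For compound 3 the estimated value is 60000 nM, with an expected range of 25000 nM to 120000 nM.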

Compound 3, half-maximal cytotoxic concentration: > 50000 nM
Compound 3: only a limit was reported; the forecaster's own chance of this, stated with the estimate: 60%; the middle value does not contradict the limit.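

In this assay compound 3 gives > 50000 nM, a limit of the assay and not a number. No step among compound 1, compound 2 and compound 3 can therefore be read: the limit of > 50000 nM in this assay, at which 2 of the 3 values shown sit.

The compounds shown leave open how far compound 2 and compound 3 lie from compound 1, and from each other.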